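Estimating compound 3 after a phenyl substituent swap

The source may report more compounds than this note shows. Statements on the series, on what has been measured and on what is new or still open speak of the compounds shown alone.

compound 1 `COc1ccccc1N1CCN(CCCOc2ccc3c(c2)CCC3)CC1`: 19%
compound 2 `CC(=O)c1ccc(N2CCN(CCCOc3ccc4c(c3)CCC4)CC2)cc1`: 0%

In a functional assay on the whole organism for inhibition, with Mus musculus as the target, at a dose of 25 mg/kg by the oral route (a lower number here means less inhibition, a higher number more inhibition at the dose given (going by the name of the read-out)), compound 2 gives 0%, the lowest of the two numbers, while compound 1 gives 19%. Compound 3 `O=[N+]([O-])c1ccccc1N1CCN(CCCOc2ccc3c(c2)CCC3)CC1` is the next candidate; it differs from compound 2 in one place:

2-nitrophenyl in place of 4-acetylphenyl on an amine nitrogen in a ring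

Among the compounds with values here, only one measured step bears on such a change: a number 19 percentage points lower from compound 1 to compound 2 (beyond the scatter), showing that the group on this ring nitrogen can shift the read-out beyond the scatter. Within the data shown here, no step covers the nitro group itself, so the estimate leans on compound 1 and compound 2 alone. Compound 3 is expected to climb by a number 15 percentage points higher from compound 2 to compound 3 (beyond the scatter), to an estimated 15% (range 0% to 35%).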

Compound 3, a percentage reported as inhibition, in the whole organism at one dose (the size of the read-out at that dose, not a potency): 43%
For compound 3 the middle estimate is 28 percentage points below the measured one; the measured number lies above the stated range.
By their numbers in this assay, from the lowest: compound 2; then compound 1; then compound 3.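

Changing the group on this ring nitrogen can raise the number in this assay as well as lower it: 2-nitrophenyl in place of 4-acetylphenyl gives a number 43 percentage points higher from compound 2 to compound 3 (beyond the scatter). Nitro in place of methoxy on an aromatic carbon gives a number 24 percentage points higher from compound 1 to compound 3 (beyond the scatter), so swapping that single substituent is enough to move the read-out beyond the scatter. Nothing measured here explains this rise.

2-nitrophenyl and 4-acetylphenyl differ in both the substituent and its numbered place on the phenyl ring, so the compounds shown do not separate those two changes. From the compounds shown here alone, how an amine or a carboxylic acid on that aromatic carbon would read also remains open.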